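Fluoro Substitution on the Anilide Ring of Two Related Amides

The compounds below may be only part of what the source reports. "The series", "measured", "known", "first", "only" and "open" are said of these compounds alone.

Measured compounds:
compound 1, `Cc1ccc(-c2ccc(C(=O)Nc3ccc(Oc4ccnc5[nH]ccc45)cc3)nc2)cc1`, > 10000 nM
compound 2, `O=C(Nc1ccc(Oc2ccnc3[nH]ccc23)cc1)c1cc(-c2ccccc2)ccn1`, 3270 nM
compound 3, `Cc1ccc(-c2ccc(C(=O)Nc3ccc(Oc4ccnc5[nH]ccc45)c(F)c3)nc2)cc1`, 2640 nM

The study looks at three measured amides and one that has not yet been measured, all tested in a functional assay on PC-3 cells (Homo sapiens) for cytotoxicity, read by MTT assay, with a stated time of 72 h; a lower number here means a stronger inhibitor, a higher number a weaker inhibitor. Compound 1 reports only a limit in this assay, > 10000 nM, and that is all that is known of it (the limit of > 10000 nM in this assay, at which 1 of the 3 values shown sits). Compound 2 gives 3270 nM in this assay. Compound 3 gives 2640 nM in this assay. The values of compound 2 and compound 3 lie within the usual scatter of each other, so neither can be ranked against the other.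

Compound 3 differs from compound 1 in one place only:
fluoro in place of hydrogen on an aromatic carbon
This change produces an at least 3.7-fold lower number from compound 1 to compound 3 (0.57 log units; beyond the scatter).

Compound 2 and compound 1 carry different cores; the difference between the two cores is not broken down here.

The unmeasured compound 4, `O=C(Nc1ccc(Oc2ccnc3[nH]ccc23)c(F)c1)c1cc(-c2ccccc2)ccn1`, relates to compound 2 exactly as compound 3 relates to compound 1:
fluoro in place of hydrogen on an aromatic carbon
The place of the change is the same in both pairs, so this is the same change made on the core of compound 2.

Because the step of an at least 3.7-fold lower number from compound 1 to compound 3 (0.57 log units; beyond the scatter) is a clear one, the same change on compound 2 is expected to lower its number too, and the estimated step is a 3.3-fold lower number from compound 2 to compound 4 (0.51 log units; beyond the scatter). Going by these compounds, since the earlier step starts from a limit, its true size is unknown, and the expectation for compound 4 is held wide. Compound 4 is expected to give about 1000 nM in this assay, with an estimated range from 300 nM to 3500 nM.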

Compound 4, half-maximal inhibitory concentration: > 10000 nM
Compound 4 gave a limit, no number; the forecaster's own chance of this, stated with the estimate: 2%; middle value at least 10-fold (1.00 log units) from the limit.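

In this assay compound 4 gives > 10000 nM, which is a limit of the assay and not a number. The fluoro in place of hydrogen on an aromatic carbon here gives an at least 3.0-fold higher number from compound 2 to compound 4 (0.48 log units; beyond the scatter), so in these two pairs the change does not carry from one core to the other, and its direction reverses: the same change on two cores in this assay, an at least 3.7-fold lower number (0.57 log units; beyond the scatter) from compound 1 to compound 3 and an at least 3.0-fold higher number (0.48 log units; beyond the scatter) from compound 2 to compound 4, at least 11-fold (1.06 log units) apart, beyond the scatter of two such steps. This shows that the result of the change depends on the core it is made on, at least for these two cores, but it does not give the true size of either step, and it gives no general rule for the series, for two of the values are limits and not numbers: the limit of > 10000 nM in this assay, at which 2 of the 4 values shown sit.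

The compounds shown leave open how far above the limit compound 1 and compound 4 really lie, and which way the same fluoro change would go on any third core. They also leave open whether another group at the same place, such as chloro, methyl or methoxy, would follow compound 3 or compound 4 in this assay.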